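A few compounds are considered here, and "the series" means these few. Any claim that something is new, unique, unknown or untested is made for them only; others in the source may bear on it.

Working notes on the series. In an ADME assay on HepG2 cells (Homo sapiens) for inhibition, read by fluorescence and resazurin assay, with a stated time of 72 h (on this read-out lower numbers stand for stronger inhibition and higher numbers for weaker inhibition), compound 1 (`CN1CCN(c2ccc(Nc3nccc(Nc4ccc5nc[nH]c5c4)n3)cc2)CC1`) reads > 25000 nM, which is a limit of the assay and not a number. Compound 1 thus stands at the limit of > 25000 nM in this assay, at which 1 of the 2 values shown sits. Compound 2 (`Cc1cc(Nc2nccc(Nc3ccc4nc[nH]c4c3)n2)ccc1N1CCN(C)CC1`) gives 15000 nM. For the measured compounds named here, the only measured step is an at least 1.6-fold lower number from compound 1 to compound 2 (0.22 log units; that floor lies within the scatter), and its change is methyl in place of hydrogen on an aromatic carbon. Compound 3 (`O=C(O)c1ccc(Nc2nccc(Nc3ccc4nc[nH]c4c3)n2)cc1`) has carboxy in place of 4-methylpiperazin-1-yl on an aromatic carbon, para to a large group: carboxy in place of 4-methylpiperazin-1-yl on an aromatic carbon. Going by the values given here, no measured step replaces that group, so the step to compound 2 offers only indirect guidance. On the strength of an at least 1.6-fold lower number from compound 1 to compound 2 (0.22 log units; that floor lies within the scatter), no step beyond the scatter is expected in this assay, in either direction. The estimated step is a step that the limit leaves unreadable from compound 1 to compound 3. For compound 3 the expected value is 30000 nM, with an estimated range from 12000 nM to 100000 nM.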

Compound 3, half-maximal inhibitory concentration: > 25000 nM
Compound 3: a limit, no number; the forecaster's own chance of this, stated with the estimate: 70%; the middle value is on the limit's open side.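

In this assay compound 3 reads > 25000 nM, which is a limit of the assay and not a number. For the compounds shown here, compound 1 also stands at a limit, so no step between compound 1 and compound 3 can be read. Still open, as far as these compounds go, is whether carboxy in place of 4-methylpiperazin-1-yl shifts this read-out at all, and in which direction.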